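From 4-chlorophenyl to 2-chlorophenyl

The source may report more compounds than this note shows. Statements on the series, on what has been measured and on what is new or still open speak of the compounds shown alone.

In a functional assay on CaEs17 cells (Homo sapiens) for cytotoxicity, read by MTT assay, with a stated time of 72 h (a lower number here means a stronger inhibitor, a higher number a weaker inhibitor), compound 1 (`C=C1C(=O)[C@@]23C(=O)OC[C@]4(C(=O)CCC(C)(C)[C@H]4C=O)[C@@H]2CC[C@@H]1[C@H]3OC(=O)c1ccc(F)cc1`) gives 8310 nM and compound 2 (`C=C1C(=O)[C@@]23C(=O)OC[C@]4(C(=O)CCC(C)(C)[C@H]4C=O)[C@@H]2CC[C@@H]1[C@H]3OC(=O)c1ccc(Cl)cc1`) stands lowest of the two at 2550 nM for now. Compound 3 (`C=C1C(=O)[C@@]23C(=O)OC[C@]4(C(=O)CCC(C)(C)[C@H]4C=O)[C@@H]2CC[C@@H]1[C@H]3OC(=O)c1ccccc1Cl`) carries 2-chlorophenyl in place of 4-chlorophenyl on a carbonyl carbon. Within the data shown here, the one measured step (a 3.3-fold lower number from compound 1 to compound 2 (0.51 log units; beyond the scatter)) swaps the halogen rather than moving it, so it offers only a rough scale. In this assay a small step to a higher number is expected, perhaps no larger than the scatter (a 1.6-fold higher number from compound 2 to compound 3 (0.20 log units; within the scatter)). The estimate for compound 3 is 4000 nM (expected range 1500 nM to 10000 nM).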

Compound 3, half-maximal inhibitory concentration: 2010 nM
Compound 3: the middle estimate sits 2.0-fold (0.30 log units) above what was measured, within the range that was stated.
By their numbers in this assay, from the lowest: compounds 3 and 2 (each within the scatter of the next); then compound 1.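

In this assay, 2-chlorophenyl in place of 4-chlorophenyl on a carbonyl carbon gives a 1.3-fold lower number from compound 2 to compound 3 (0.10 log units; within the scatter) and so leaves the two chlorophenyl groups indistinguishable here. With 4-fluorophenyl as the reference, a 4.1-fold lower number from compound 1 to compound 3 (0.62 log units; beyond the scatter) is a modest step, and both chlorophenyl groups now stand apart from that group in this assay. Nothing available bears on the reason for either step. Still open, on these data alone, is whether an amine or a carboxylic acid in place of the chlorine would keep this level, and whether a saturated cyclohexyl group could replace the aromatic ring.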